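The compounds below may be only part of what the source reports. "The series", "measured", "known", "first", "only" and "open" are said of these compounds alone.

Compound 2 `COc1ccc(CN(C(=O)CSc2nc3ccccc3s2)c2cc(OC)c(OC)c(OC)c2)cc1N` gives 491 nM in a functional assay on HCT-116 cells (Homo sapiens) for antiproliferative activity, read by MTT assay, with a stated time of 48 h (on this read-out lower numbers stand for stronger inhibition and higher numbers for weaker inhibition), the second highest of the three numbers measured. Compound 1 `COc1ccc2nc(SCC(=O)N(Cc3ccc(OC)c(O)c3)c3cc(OC)c(OC)c(OC)c3)sc2c1` gives 352 nM and compound 3 `COc1ccc(CN(C(=O)CSc2nc3c(C)cccc3s2)c2cc(OC)c(OC)c(OC)c2)cc1O` gives 852 nM, and compound 2 stands within the scatter of both. Among the measured compounds shown here, the only measured single-place step, a 2.4-fold higher number from compound 1 to compound 3 (0.38 log units; beyond the scatter), concerns the group on the sulfur and not the place where compound 4 differs. Compound 4 `COc1ccc(CN(C(=O)CSc2nc3ccccc3s2)c2cc(OC)c(OC)c(OC)c2)cc1Br` differs from compound 2 by bromo in place of amino on an aromatic carbon. For the measured compounds named here, no measured step bears on bromo in place of amino on an aromatic carbon, so no step beyond the scatter is expected in either direction. Compound 4 is therefore expected to give 500 nM, between 200 nM and 1300 nM, in this assay. The expected step is a 1.0-fold higher number from compound 2 to compound 4 (0.01 log units; within the scatter).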

Compound 4, half-maximal inhibitory concentration: 4550 nM
Estimate against measurement, compound 4: 9.1-fold (0.96 log units) below, outside the stated range (above it).
By their numbers in this assay, from the lowest: compounds 1, 2 and 3 (each within the scatter of the next, the first and the last beyond it); then compound 4.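

In this assay, bromo in place of amino on this aromatic carbon, ortho to a methoxy group, brings a 9.3-fold higher number from compound 2 to compound 4 (0.97 log units; beyond the scatter) and lies beyond the scatter. The earlier compounds shown here showed a change only in the group on the sulfur; this step shows that the number also depends on what this position carries. No measurement given here accounts for the step.

From the compounds shown here alone, it remains open whether chloro, methyl or dimethylamino at this position would stay close to compound 2 or move towards compound 4. Going by these compounds, whether the same change would carry over to other groups on the sulfur is also open.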